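From acetamido to a hydroxylated amide chain

The compounds below may be only part of what the source reports. "The series", "measured", "known", "first", "only" and "open" are said of these compounds alone.

Measured in a functional assay on A2780 cells (Homo sapiens) for antiproliferative activity, read by MTT assay, with a stated time of 48 h; a lower number here means a stronger inhibitor, a higher number a weaker inhibitor
Compound 1 `CCNCC(=O)Nc1cc(OC)ccc1C(=O)c1ccc(OC)c2c1C=CC(C)(C)O2` gives 4090 nM
Compound 2 `C=C(c1cc(OC)c(OC)c(OC)c1)c1ccc(OC)c(O)c1NC(C)=O` gives 170 nM

Of these two, compound 2 has the lower number, and the gap to compound 1 (4090 nM) lies well beyond the scatter. The two compounds differ in more than one place, so their gap says nothing about any single change. Compound 3 `C=C(c1cc(OC)c(OC)c(OC)c1)c1ccc(OC)c(O)c1NC(=O)CO` differs from compound 2 in one place (hydroxy in place of hydrogen on a saturated chain carbon bound to a carbonyl carbon) with hydroxy in place of hydrogen on a saturated chain carbon bound to a carbonyl carbon, turning acetamido into ((hydroxymethyl)carbonyl)amino. For the measured compounds named here, no measured pair shows this change, so the expectation starts from compound 2 (170 nM). It is for a small rise in the number in this assay and possibly none beyond the scatter. The estimated move is a 1.5-fold higher number from compound 2 to compound 3 (0.17 log units; within the scatter) and no larger one is expected. Compound 3 is expected at 250 nM (estimated range 70 nM to 900 nM).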

Compound 3, half-maximal inhibitory concentration: 20 nM
The estimate for compound 3 lay 13-fold (1.10 log units) above the measured number; the whole stated range lies above it.
By their numbers in this assay, from the lowest: compound 3; then compound 2; then compound 1.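

Set in this assay, hydroxy in place of hydrogen on a saturated chain carbon bound to a carbonyl carbon gives an 8.5-fold lower number from compound 2 to compound 3 (0.93 log units; beyond the scatter) and so moves the number down beyond the scatter. This is the first single change shown at this position, and it shows that turning acetamido into ((hydroxymethyl)carbonyl)amino favours activity here, which the gap between compound 1 and compound 2 could not show because those two differ in more than one place. No measurement shown here accounts for the size of this step.

On these data alone, it remains open whether the gain is specific to the hydroxy or would also appear with a methoxy, a carboxylic acid or a longer chain carrying the hydroxy on that carbon. As far as these compounds go, it also remains open whether the same change would lower the number on the core of compound 1.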